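The compounds below may be only part of what the source reports. "The series", "measured", "known", "first", "only" and "open" are said of these compounds alone.

In a functional assay on V79 cells (Cricetulus griseus) for cytotoxicity, read by colony formation (on this read-out higher numbers stand for weaker inhibition and lower numbers for stronger inhibition), compound 3 (`COc1c(N2CC(C)NC(C)C2)c(F)cc2c(=O)c(C(=O)O)cn(C3CC3)c12`), which carries a 3,5-dimethylpiperazin-1-yl group, gives > 500 ug/mL. That figure is only a limit of the assay and not a number. Its two relatives on the same core give real numbers: compound 1 (`COc1c(N2CCCC2)c(F)cc2c(=O)c(C(=O)O)cn(C3CC3)c12`), with pyrrolidin-1-yl, gives 150 ug/mL, and compound 2 (`COc1c(N2CCNCC2)c(F)cc2c(=O)c(C(=O)O)cn(C3CC3)c12`), with piperazin-1-yl, gives 82 ug/mL. Between those two lies a 1.8-fold lower number from compound 1 to compound 2 (0.26 log units; within the scatter), so swapping one plain ring for the other shows no real effect here.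

Compound 4 (`COc1c(N2CCC(C)(N)C2)c(F)cc2c(=O)c(C(=O)O)cn(C3CC3)c12`) has 3-amino-3-methylpyrrolidin-1-yl in place of 3,5-dimethylpiperazin-1-yl on an aromatic carbon. The 3,5-dimethylpiperazin-1-yl group is what sets compound 3 apart, as shown by an at least 3.3-fold higher number from compound 1 to compound 3 (0.52 log units; beyond the scatter) and by an at least 6.0-fold higher number from compound 2 to compound 3 (0.78 log units; beyond the scatter). Compound 4 gives up that group and returns to the five-membered ring of compound 1, which gives 150 ug/mL. Going by the values given here, no tested compound shows what the added amino and methyl groups do on that ring, so the uncertainty stays wide.

The expected change is an at least 6.2-fold lower number from compound 3 to compound 4 (0.79 log units; beyond the scatter), towards a lower number and thus stronger inhibition. For compound 4 the estimated value is 80 ug/mL, with an expected range from 20 ug/mL to 300 ug/mL.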

Compound 4, half-maximal inhibitory concentration: 38 ug/mL
Compound 4: the middle estimate sits 2.1-fold (0.32 log units) above what was measured, within the range that was stated.
By their numbers in this assay, from the lowest: compound 4; then compounds 2 and 1 (each within the scatter of the next). At a limit, above all of these: compound 3.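

The earlier compounds shown here showed this position, on an aromatic carbon ortho to a fluoro group and ortho to a methoxy group, changing the read-out only upwards, with 3,5-dimethylpiperazin-1-yl. In this assay, 3-amino-3-methylpyrrolidin-1-yl now shows that the same position can also move it downwards, towards stronger inhibition, with a 3.9-fold lower number from compound 1 to compound 4 (0.60 log units; beyond the scatter) and with a 2.2-fold lower number from compound 2 to compound 4 (0.33 log units; beyond the scatter) as well as a large change against the dimethylpiperazine, an at least 13-fold lower number from compound 3 to compound 4 (1.11 log units; beyond the scatter). Compound 3 gives only a limit of the assay, so that last step has a lower bound and no exact size: the limit of > 500 ug/mL in this assay, at which 1 of the 4 values shown sits.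

Compound 4 differs from compound 1 by both an amino group and a methyl group on the ring, so the compounds shown cannot separate their contributions, which 3-aminopyrrolidin-1-yl and 3-methylpyrrolidin-1-yl could do. From the compounds shown here alone, it also remains open whether 3-methylpiperazin-1-yl would stay close to compound 2 or move towards compound 3.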